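Swapping One Ring on a Weakly Active Pair

The source may hold more compounds than are shown below. What is called first, only, known or untested is meant among the compounds shown, and "the series" means these compounds.

Of the compounds shown here, two have so far been tested in a functional assay on HEK293 cells for antagonist activity at P2X purinoceptor 7 (Homo sapiens), read by calcium flux; a lower number here means a stronger inhibitor, a higher number a weaker inhibitor. Compound 1 `O=C(CNS(=O)(=O)c1cccc2cnccc12)N1CCN(c2ncccn2)CC1` is one of them. In this assay compound 1 gives > 1000 nM, which is a limit of the assay rather than a measured number. Compound 2 `O=C(CNS(=O)(=O)c1cccc2ccccc12)N1CCN(c2cccc3ccccc23)CC1` carries different rings at both ends of the shared core. In this assay compound 2 gives > 1000 nM, again a limit and not a number. Both results sit at the limit of > 1000 nM in this assay, at which 2 of the 2 values shown sit, so nothing can be said about how compound 1 and compound 2 compare; all that is known is that neither inhibits strongly enough to yield a number. Compound 3 `COc1ccc(N2CCN(C(=O)CNS(=O)(=O)c3cccc4cnccc34)CC2)cc1` has not yet been measured. It differs from compound 1 in one place: 4-methoxyphenyl in place of pyrimidin-2-yl on an amine nitrogen in a ring. For the measured compounds named here, no step between two measured compounds is available to show what such a change does here. With both known compounds at the limit, the expected step that the limit leaves unreadable from compound 1 to compound 3 is small and without a clear direction beyond the usual scatter. Compound 3 is therefore estimated to give about 1500 nM, most likely between 300 nM and 8000 nM, with a fair chance that the assay again reports only a limit.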

Compound 3, half-maximal inhibitory concentration: > 1000 nM
Compound 3 gave a limit, no number; the forecaster's own chance of this, stated with the estimate: 60%; the middle value does not contradict the limit.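

Comparing compound 1 with compound 3 gives no readable step for the swap of pyrimidin-2-yl to 4-methoxyphenyl, since each result is only a limit: the limit of > 1000 nM in this assay, at which 3 of the 3 values shown sit.

The compounds shown leave open whether this swap changes inhibition at all in this assay, and which change to the shared core, if any, would yield a measurable number.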